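This account rests on a few compounds, and the source may have more. Where it says the series, first, only, none or still open, it means among the compounds named here.

Measured so far:
compound 1 `Cc1ccc(NC(=O)COc2ccc3cc(/C=C4/SC(=O)NC4=O)ccc3c2)cc1` — 9000 nM
compound 2 `O=C(COc1ccc2cc(/C=C3/SC(=O)NC3=O)ccc2c1)Nc1cccc(C(F)(F)F)c1` — a limit, > 50000 nM

For the measured compounds named here, compound 1 is the only compound in the pair with a number in an assay on isolated protein for inhibition of histone deacetylase 8 (Homo sapiens), with a stated time of 1 h; on this read-out higher numbers stand for weaker inhibition and lower numbers for stronger inhibition; compound 2 returns no number in this assay, only a limit. Between them the single measured step is an at least 5.5-fold higher number from compound 1 to compound 2 (0.74 log units; beyond the scatter), and its size is set by the limit of > 50000 nM in this assay, at which 1 of the 2 values shown sits, so the true gap may be larger than the limit tells.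

Compound 3 `O=C(COc1ccc2cc(/C=C3/SC(=O)NC3=O)ccc2c1)Nc1ccc([N+](=O)[O-])cc1` is obtained from compound 1 by nitro in place of methyl on an aromatic carbon. Going by the values given here, the one measured step bears on this only loosely: it also exchanges the group on the amide-type nitrogen, and it moved this assay toward a higher number, whereas here the aryl ring keeps its substitution pattern and only the group changes from methyl to nitro. Among the compounds with values here, no nitro-bearing compound has been measured, so the direction rests on the single measured exchange. A step toward a higher number is expected, of roughly a 2.2-fold higher number from compound 1 to compound 3 (0.35 log units; beyond the scatter), with a real chance that the assay again returns only a limit. Compound 3 is therefore estimated at 20000 nM, within 7000 nM to 60000 nM.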

Compound 3, half-maximal inhibitory concentration: 4000 nM
Compound 3: middle estimate off by 5.0-fold (0.70 log units), on the high side; measured number below the stated range.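

In this assay, the group para to a large group on the aryl ring can move the number down as well as up: nitro in place of methyl gives a 2.3-fold lower number from compound 1 to compound 3 (0.35 log units; beyond the scatter). The comparison between the two exchanged aryl groups gives an at least 12-fold lower number from compound 2 to compound 3 (1.09 log units; beyond the scatter), so the weak result with 3-(trifluoromethyl)phenyl does not extend to every replacement of 4-methylphenyl on the amide-type nitrogen. Compound 2 stands only as a limit, so the full size of that second step stays unknown: the limit of > 50000 nM in this assay, at which 1 of the 3 values shown sits.

The compounds shown leave open whether the gap between 4-nitrophenyl and 3-(trifluoromethyl)phenyl follows from the identity of the group or from its place on the ring, since the two differ in both. They also leave open how far the trend from methyl to nitro extends, and an amine or a carboxylic acid in place of the nitro on the same ring would show whether this assay moves further in the same direction or turns back.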